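This account rests on a few compounds, and the source may have more. Where it says the series, first, only, none or still open, it means among the compounds named here.

Measured compounds in an assay on CHO cells for displacement of a labelled ligand from adenosine receptor A3 (Homo sapiens); on this read-out higher numbers stand for weaker inhibition and lower numbers for stronger inhibition:
- compound 1 `CCCn1c(=O)[nH]c2nc(-c3cnn(Cc4cccc(F)c4)c3)[nH]c2c1=O` gives 160 nM.
- compound 2 `CCCCn1c(=O)[nH]c2nc(-c3cnn(Cc4cccc(C(F)(F)F)c4)c3)[nH]c2c1=O` gives only a limit of the assay, > 9000 nM.
- compound 3 `CC(C)Cn1c(=O)[nH]c2nc(-c3cnn(Cc4cccc(F)c4)c3)[nH]c2c1=O` gives 1600 nM.

Compound 3 holds the highest of the two numbers measured; its nearest neighbour is compound 1, the step being a 10-fold higher number from compound 1 to compound 3 (1.00 log units; beyond the scatter). The third value shown is a limit of the assay, (the limit of > 9000 nM in this assay, at which 1 of the 3 values shown sits), and belongs to compound 2.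

Compound 4 `CC(C)Cn1c(=O)[nH]c2nc(-c3cnn(Cc4cccc(C(F)(F)F)c4)c3)[nH]c2c1=O` differs from compound 3 by trifluoromethyl in place of fluoro on an aromatic carbon. Among the measured compounds shown here, no measured step isolates this change: compound 1 and compound 2 differ in the same way but also in the alkyl chain on the core, so their pair cannot be read as a single step. The readings of compound 1 and compound 2 nonetheless point towards weaker binding, and compound 3 already sits high. A step of a 9.4-fold higher number from compound 3 to compound 4 (0.97 log units; beyond the scatter) is therefore expected, and compound 4 is estimated at 15000 nM, within 3000 nM to 60000 nM, with a fair chance that only a limit is reported.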

Compound 4, inhibition constant: > 9000 nM
Compound 4 gave a limit, no number (the forecaster's own chance of this, stated with the estimate: 65%); the middle value is on the limit's open side.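

On the chain of compound 3, the change from 3-fluorophenyl to 3-(trifluoromethyl)phenyl now has a single-change reading in this assay (an at least 5.6-fold higher number from compound 3 to compound 4 (0.75 log units; beyond the scatter)), which the pair of compound 1 and compound 2 could not give. The step from compound 2 to compound 4 cannot be read, so the chain change remains unresolved with trifluoromethyl in place. Compound 4 gives a limit of the assay and not a number: the limit of > 9000 nM in this assay, at which 2 of the 4 values shown sit.

From the compounds shown here alone, the full size of the trifluoromethyl step remains open. Also open, going by these compounds, is whether chloro, methoxy, an amine or a carboxylic acid on this aromatic carbon would give a measurable value in this assay on either chain.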